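Replacing a chloromethyl end in compound 2 with methoxycarbonyl

The compounds below may be only part of what the source reports. "The series", "measured", "known", "first", "only" and "open" are said of these compounds alone.

Compound 1 `CN1CCN(c2ccc(C3=NNC(c4ccc(N(C)C)cc4)C3)cc2)CC1` gives 31.2% in a functional assay on HCC1806 cells (Homo sapiens) for inhibition, read by sulforhodamine B assay, tested at 10 uM; a lower number here means less inhibition, a higher number more inhibition at the concentration tested (going by the name of the read-out). Compound 2 `CN1CCN(c2ccc(C3=NN(C(=O)CCCl)C(c4ccc(N(C)C)cc4)C3)cc2)CC1` gives 1.7%, the lower of the two numbers, after the step of a number 29.5 percentage points lower from compound 1 to compound 2 (beyond the scatter). Compound 3 `COC(=O)CC(=O)N1N=C(c2ccc(N3CCN(C)CC3)cc2)CC1c1ccc(N(C)C)cc1` differs from compound 2 by methoxycarbonyl in place of chloromethyl on a saturated chain carbon bound to a carbonyl carbon. For the measured compounds named here, no measured step changes this chain end; the only step, a number 29.5 percentage points lower from compound 1 to compound 2 (beyond the scatter), concerns adding the whole (2-chloroethyl)carbonyl group and so bears on the change only indirectly. With compound 2 already near the bottom of the scale, a step no larger than the scatter is expected, a number 4.3 percentage points higher from compound 2 to compound 3 (within the scatter). Compound 3 is therefore estimated at 6%, within 0% to 22%.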

Compound 3, a percentage reported as inhibition, at one concentration (the size of the read-out at that concentration, not a potency): -8.3%
The estimate for compound 3 lay 14.3 percentage points above the measured number; measured number below the stated range.
By their numbers in this assay, from the lowest: compounds 3 and 2 (each within the scatter of the next); then compound 1.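

In this assay, methoxycarbonyl in place of chloromethyl on a saturated chain carbon bound to a carbonyl carbon gives a number 10 percentage points lower from compound 2 to compound 3 (within the scatter), so the two chain ends cannot be told apart here. The step of a number 39.5 percentage points lower from compound 1 to compound 3 (beyond the scatter) shows that the fall seen with the (2-chloroethyl)carbonyl group also occurs without chlorine in the chain. No evidence on the cause accompanies these numbers.

As far as these compounds go, whether an amine or a carboxylic acid at this chain end would lift the number remains open. So does whether a longer chain or a plain acetyl group on the ring nitrogen would do so.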